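Benzyl to allyl on the sulfur of a uridine diphosphate

The source may hold more compounds than are shown below. What is called first, only, known or untested is meant among the compounds shown, and "the series" means these compounds.

Measured compounds:
- compound 1, `O=c1ccn([C@@H]2O[C@H](COP(=O)(O)OP(=O)(O)O)C[C@H]2O)c(=O)[nH]1`, 2500 nM in an in vitro functional assay on 1321-N1 cells for agonist activity at P2Y purinoceptor 6 (Homo sapiens); on this read-out lower numbers stand for an effect already at smaller amounts and higher numbers for an effect only at larger amounts of compound
- compound 2, `Cn1c(=O)ccn([C@@H]2O[C@H](COP(=O)(O)OP(=O)(O)O)[C@@H](O)[C@H]2O)c1=O`, 3300 nM in this assay
- compound 3, `O=c1nc(SCc2ccccc2)ccn1[C@@H]1O[C@H](COP(=O)(O)OP(=O)(O)O)[C@@H](O)[C@H]1O`, 800 nM in this assay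

Among the three measured compounds, compound 3 has the lowest number in this assay; its gap to compound 1 and its larger gap to compound 2 both lie beyond the usual scatter, so compound 3 acts at smaller amounts than either.

Compound 4, `C=CCSc1ccn([C@@H]2O[C@H](COP(=O)(O)OP(=O)(O)O)[C@@H](O)[C@H]2O)c(=O)n1`, keeps the sulfur-bearing core of compound 3 and differs from it by a single change: vinyl in place of phenyl on a saturated chain carbon bound to a sulfur. Among the compounds with values here, no measured pair shows what such a shortening of the group on the sulfur does in this assay, so the expectation for compound 4 rests on its closeness to compound 3 alone. The step of a 1.9-fold higher number from compound 3 to compound 4 (0.27 log units; within the scatter) is expected to be small, toward a somewhat higher number, and may well stay within the scatter. Compound 4 is therefore estimated at 1500 nM in this assay, with a range from 400 nM to 6000 nM.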

Compound 4, half-maximal effective concentration: 560 nM
For compound 4 the middle estimate is 2.7-fold (0.43 log units) above the measured one; the measured number falls inside the stated range.
By their numbers in this assay, from the lowest: compounds 4 and 3 (each within the scatter of the next); then compounds 1 and 2 (each within the scatter of the next).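

In this assay, within the data shown here, replacing benzylsulfanyl with allylsulfanyl gives a 1.4-fold lower number from compound 3 to compound 4 (0.15 log units; within the scatter), the first reading of a change at this position. The phenyl ring on the saturated chain carbon bound to the sulfur can therefore give way to vinyl, with 2 heavy atoms entering where 6 leave, and the two compounds still cannot be told apart in this assay. Nothing shown explains why the two groups read alike.

The compounds shown leave open whether the double bond of allyl plays any part, which a saturated propyl group on the sulfur could test, and how a longer chain or a cyclohexylmethyl group would read there. They also leave open what happens when an amine or an ether oxygen takes the place of the sulfur.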